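The compounds below may be only part of what the source reports. "The series", "measured", "known", "first", "only" and "open" are said of these compounds alone.

Measured compounds:
- compound 1 `COc1ccc(C(=O)/C=C/c2ccc(Br)cc2)c2c1C=CC(C)(C)O2` — > 10000 nM, a limit of the assay
- compound 2 `COc1ccc(C(=O)/C=C/c2ccc(N(c3ccccc3)c3ccccc3)cc2)c2c1C=CC(C)(C)O2` — > 10000 nM, a limit of the assay
- compound 3 `COc1ccc(C(=O)/C=C/c2ccc(OC)c(OC)c2OC)c2c1C=CC(C)(C)O2` — > 10000 nM, a limit of the assay

Of the compounds shown here, three built on the same core have been tested in a functional assay on SK-OV-3 cells (Homo sapiens) for antiproliferative activity, read by MTT assay, with a stated time of 24 h; a lower number here means a stronger inhibitor, a higher number a weaker inhibitor. Compound 1 gives > 10000 nM, which is a limit of the assay and not a number. Compound 2 likewise gives > 10000 nM, a limit. Compound 3 gives > 10000 nM, again a limit. For the measured compounds named here, compound 1 therefore stands at the limit of > 10000 nM in this assay, at which 3 of the 3 values shown sit, and no ordering among the three and no step between them can be computed.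

Compound 4 `COc1ccccc1/C=C/C(=O)c1ccc(OC)c2c1OC(C)(C)C=C2` has not yet been measured in this assay. It differs from compound 1 in a single place: 2-methoxyphenyl in place of 4-bromophenyl on a double-bonded chain carbon bound to a double-bonded chain carbon. Going by the values given here, because compound 1 sits at the limit of > 10000 nM in this assay, at which 3 of the 3 values shown sit, there is no measured step that would point in either direction for this change. The expectation for the step in this assay is therefore none beyond the scatter, with compound 4 most likely reported at the same limit. Compound 4 is expected to give about 15000 nM, within a range of 5000 nM to 50000 nM. The estimated step that the limit leaves unreadable from compound 1 to compound 4 is expected to lie within the usual scatter.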

Compound 4, half-maximal inhibitory concentration: > 10000 nM
Compound 4: only a limit was reported (the forecaster's own chance of this, stated with the estimate: 80%); the middle value is on the limit's open side.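

Compound 1 and compound 4 both stand at a limit and not at a number, so no step between them can be read in this assay: the limit of > 10000 nM in this assay, at which 4 of the 4 values shown sit.

The compounds shown leave open how 2-methoxyphenyl and 4-bromophenyl truly compare, and whether any compound on the shared core reaches a readable value in this assay.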